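Cyano on the pyrazole across two cores

The source may hold more compounds than are shown below. What is called first, only, known or untested is meant among the compounds shown, and "the series" means these compounds.

Measured compounds:
compound 1, `O=C(N1CCCN(Cc2ccc(OCc3ccccc3)cc2)CC1)n1cccn1`, 960 nM
compound 2, `N#Cc1cnn(C(=O)N2CCCN(Cc3ccc(OCc4ccccc4)cc3)CC2)c1`, 85 nM
compound 3, `O=C(N1CCN(C(c2ccc(OCc3ccccc3)cc2)c2ccc(OCc3ccccc3)cc2)CC1)n1cccn1`, limit only, > 100000 nM

The three compounds were tested in an assay on membranes from brain for binding affinity to Monoacylglycerol lipase ABHD6 (Mus musculus), read by fluorescence, with stated times of 1 h and 30 min; on this read-out higher numbers stand for weaker inhibition and lower numbers for stronger inhibition. In this assay compound 1 gives 960 nM and compound 2 gives 85 nM. The change from compound 1 to compound 2 is cyano in place of hydrogen on an aromatic carbon and makes a step of an 11-fold lower number from compound 1 to compound 2 (1.05 log units; beyond the scatter).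

Compound 3 carries a different core; how it differs from the core of compound 1 is not broken down here. For compound 3 this assay gives only a limit, > 100000 nM, which is the limit of > 100000 nM in this assay, at which 1 of the 3 values shown sits.

Compound 4, `N#Cc1cnn(C(=O)N2CCN(C(c3ccc(OCc4ccccc4)cc3)c3ccc(OCc4ccccc4)cc3)CC2)c1`, has not yet been measured in this assay. The change from compound 3 to compound 4 is cyano in place of hydrogen on an aromatic carbon; the place is described in the same words as for the change from compound 1 to compound 2, so it is the same change made on the core of compound 3. Because compound 3 sits at > 100000 nM, only a limit is known for the starting point of this step. The expectation for compound 4 rests on the step of an 11-fold lower number from compound 1 to compound 2 (1.05 log units; beyond the scatter) carried over to the core of compound 3, and compound 4 is expected to move by about an at least 2.5-fold lower number from compound 3 to compound 4 (0.39 log units; beyond the scatter). Compound 4 is estimated at 40000 nM in this assay, expected between 4000 nM and 200000 nM, with a real chance that only a limit is reported again.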

Compound 4, half-maximal inhibitory concentration: 130000 nM
Beside the measured number, compound 4's estimate is 3.3-fold (0.51 log units) below it, within the range that was stated.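

No step from compound 3 to compound 4 can be read, because compound 3 is known only as a limit, so the new value for compound 4 has no number to be set against: the limit of > 100000 nM in this assay, at which 1 of the 4 values shown sits.

The compounds shown leave open whether cyano in place of hydrogen does anything on the core of compound 3 that compares with the step on the other core, an 11-fold lower number from compound 1 to compound 2 (1.05 log units; beyond the scatter).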